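Removing an aromatic methyl across two related antiproliferative pairs

This account rests on a few compounds, and the source may have more. Where it says the series, first, only, none or still open, it means among the compounds named here.

Compound 1 `COc1ccc2nc(-c3ccc(N/C=C\C(=O)c4ccc(OC)c(F)c4)c(C)c3)sc2c1` and compound 2 `COc1ccc2nc(-c3ccc(N/C=C\C(=O)c4ccc(OC)c(F)c4)cc3)sc2c1` share one core; compound 3 `COc1cc(C(=O)/C=C\Nc2ccc(-c3nc4cc(OC)c(OC)c(OC)c4s3)cc2C)cc(OC)c1OC` and the as yet unmeasured compound 4 `COc1cc(C(=O)/C=C\Nc2ccc(-c3nc4cc(OC)c(OC)c(OC)c4s3)cc2)cc(OC)c1OC` share another. The difference between the two cores is not broken down here. In a functional assay on A549 cells (Homo sapiens) for antiproliferative activity, read by sulforhodamine B assay, with a stated time of 48 h (on this read-out lower numbers stand for stronger inhibition and higher numbers for weaker inhibition), compound 1 gives 1400 nM, and in this assay compound 2 gives 900 nM. The change between them is hydrogen in place of methyl on an aromatic carbon, and its size was a 1.6-fold lower number from compound 1 to compound 2 (0.19 log units; within the scatter).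

In this assay, among the measured compounds shown here, compound 3 gives 23300 nM, the highest of the three numbers known so far, and its distance from both compound 1 at 1400 nM and compound 2 at 900 nM lies beyond the scatter. The change from compound 3 to compound 4 is hydrogen in place of methyl on an aromatic carbon, the same kind of change as that from compound 1 to compound 2, and both place lines read alike, so nothing about the surroundings is known to differ.

For compound 4 in this assay a step of about a 1.6-fold lower number from compound 3 to compound 4 (0.19 log units; within the scatter) is expected. For the measured compounds named here, that expectation rests on the only measured instance of this change, the step of a 1.6-fold lower number from compound 1 to compound 2 (0.19 log units; within the scatter), which was small, and on compound 3 sitting far up the scale at 23300 nM. Compound 4 is therefore estimated at 15000 nM, with a likely range from 6000 nM to 40000 nM.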

Compound 4, half-maximal inhibitory concentration: 15500 nM
Beside the measured number, compound 4's estimate is 1.0-fold (0.01 log units) below it; low and high end bracket the measured number.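

In this assay, hydrogen in place of methyl on an aromatic carbon gives a 1.5-fold lower number from compound 3 to compound 4 (0.18 log units; within the scatter), and this step agrees with the one on the other core: the same change on two cores in this assay, a 1.6-fold lower number (0.19 log units; within the scatter) from compound 1 to compound 2 and a 1.5-fold lower number (0.18 log units; within the scatter) from compound 3 to compound 4, 1.0-fold (0.01 log units) apart, within the scatter of two such steps. Within this series and this assay, the change therefore carries from one core to the other as a step that cannot be told from the scatter on either core, so the two pairs show no measurable contribution from this methyl. They do not show that the same would hold on a third core or in another assay, and two pairs within the scatter give no basis for a general rule or for any explanation of why the methyl makes so little difference.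

The compounds shown carry only methyl or hydrogen at this place on the ring, leaving open whether a larger or different group there, such as ethyl, chlorine or an amine, would produce a step beyond the scatter. They also leave open which of the several differences between the two cores matters for activity, since no pair shown isolates any one of them.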